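Compound 1 to compound 3: methoxy to hydroxy

This account rests on a few compounds, and the source may have more. Where it says the series, first, only, none or still open, it means among the compounds named here.

Among the compounds with values here, in a functional assay on LOX IMVI cells (Homo sapiens) for cytotoxicity, read by MTT assay, with a stated time of 24 h (on this read-out higher numbers stand for weaker inhibition and lower numbers for stronger inhibition), compound 1 (`COc1cc(-c2nc(-c3ccccc3)[nH]c2-c2ccnc(NCCCNS(=O)(=O)c3ccc(Br)cc3)n2)ccc1Cl`) gives 23700 nM and stands highest of the two numbers so far, while compound 2 (`COc1cc(-c2nc(-c3ccccc3)[nH]c2-c2ccnc(NCCCNS(=O)(=O)c3cccc(F)c3)n2)ccc1Cl`) gives 5110 nM as the lower one. Compound 3 (`O=S(=O)(NCCCNc1nccc(-c2[nH]c(-c3ccccc3)nc2-c2ccc(Cl)c(O)c2)n1)c1ccc(Br)cc1`) differs from compound 1 by hydrogen in place of methyl on an oxygen on an aromatic ring as methoxy gives way to hydroxy on the aromatic ring. Within the data shown here, the sole measured step (a 4.6-fold lower number from compound 1 to compound 2 (0.67 log units; beyond the scatter)) changes the group on the sulfonyl sulfur and not this oxygen, so no measured step guides size or direction here. The expected step is a 1.3-fold lower number from compound 1 to compound 3 (0.12 log units; within the scatter) and stays within the scatter. Compound 3 is expected near 18000 nM (estimated range 6000 nM to 50000 nM).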

Compound 3, half-maximal inhibitory concentration: 15500 nM
For compound 3 the middle estimate is 1.2-fold (0.06 log units) above the measured one, and the stated range covers the measured number.
By their numbers in this assay, from the lowest: compound 2; then compounds 3 and 1 (each within the scatter of the next).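

In this assay, within the data shown here, hydrogen in place of methyl on this oxygen gives a 1.5-fold lower number from compound 1 to compound 3 (0.18 log units; within the scatter), the first reading on this position, since the earlier step changed only the group on the sulfonyl sulfur. With the 4-bromophenyl group in place, methoxy and hydroxy are therefore not told apart at this position. Nothing at hand bears on a cause for this result.

As far as these compounds go, whether hydroxy behaves the same alongside the 3-fluorophenyl group of compound 2 stays open. So does whether ethoxy or an amine at this position would move the number beyond the scatter.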